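A few compounds are considered here, and "the series" means these few. Any claim that something is new, unique, unknown or untested is made for them only; others in the source may bear on it.

Measured compounds:
- compound 1, `COc1ccc(C(c2ccc(OC)cc2)N2CCN(C(=O)COc3ccc4ccccc4c3)CC2)cc1`, giving 25.6% in a functional assay on PC-12 cells (Rattus norvegicus) for cytotoxicity, read by MTT assay, with a stated time of 24 h, tested at 10 uM; on this read-out higher numbers stand for a stronger effect at the one concentration tested and lower numbers for a weaker effect
- compound 2, `O=C(COc1ccc2ccccc2c1)N1CCN(C(c2ccc(Br)cc2)c2ccc(Br)cc2)CC1`, giving 30.2% in this assay
- compound 3, `Cc1ccc(C(c2ccc(C)cc2)N2CCN(C(=O)COc3ccc4ccccc4c3)CC2)cc1`, giving 10.3% in this assay

Compound 3 stands lowest of the three numbers. Its nearest neighbour is compound 1, whose number is higher by a gap beyond the scatter, and compound 2 is further still, also beyond the scatter. The three compounds share a core and differ in the substituents on the two phenyl rings, so no single step between any two of them is counted here; only their three values are shown.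

Compound 4, `COc1ccc(OCC(=O)N2CCN(C(c3ccc(C)cc3)c3ccc(C)cc3)CC2)cc1`, has not yet been measured. It differs from compound 3 by one change: 4-methoxyphenyl in place of naphthalen-2-yl on an oxygen on a saturated carbon. Going by the values given here, since no step for such a change has been measured, the expectation rests on compound 3 alone, whose value is 10.3%. A step of modest size is expected, lying within the scatter, in no definite direction: a number 0.7 percentage points higher from compound 3 to compound 4 (within the scatter). Compound 4 is therefore estimated at 11%, with a range from 0% to 26%.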

Compound 4, a percentage reported as activity, at one concentration (the size of the read-out at that concentration, not a potency): 47.5%
Estimate against measurement, compound 4: 36.5 percentage points below; the whole stated range lies below it.
By their numbers in this assay, from the lowest: compound 3; then compounds 1 and 2 (each within the scatter of the next); then compound 4.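

Going by these compounds alone, replacing naphthalen-2-yl with 4-methoxyphenyl on an oxygen on a saturated carbon gives a number 37.2 percentage points higher from compound 3 to compound 4 (beyond the scatter) in this assay, the first step that can be read, and it shows that the read-out responds strongly to the group at this position. The change removes one aromatic ring and adds one hydrogen-bond acceptor, and this single step cannot separate those two differences. No measurement shown here offers an explanation for the step.

A plain phenyl group at this position would separate the loss of the second ring from the arrival of the methoxy group, while an ethoxy group in place of the methoxy group would test how much room the response allows there. As far as these compounds go, it also remains open whether the same change would produce a similar step on the cores of compound 1 and compound 2.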